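Swapping a Pyridyl Ring for an Isopropylphenyl Ring

A few compounds are considered here, and "the series" means these few. Any claim that something is new, unique, unknown or untested is made for them only; others in the source may bear on it.

Measured compounds:
compound 1 `CCOc1ccccc1-c1ccc(-c2nc(NC(C)C(=O)O)c3ccncc3n2)cc1`: 2.1
compound 2 `CC[C@@H](Nc1c(C#N)c(-c2ccc(-c3cccnc3C)cc2)nc2cnccc12)C(N)=O`: 1.9
compound 3 `CCOc1ccccc1-c1ccc(-c2nc3cnccc3c(C[C@H](C)C(=O)O)c2C#N)cc1`: 2.2

In a physicochemical assay for lipophilicity, read by HPLC, at pH 7.5 (on this read-out lower numbers stand for lower lipophilicity and higher numbers for higher lipophilicity), compound 2 gives the lowest of the three numbers, but compound 1 stands only slightly higher and compound 3 a little further, both within the scatter, so the three cannot be ordered. Compound 4 `CC[C@@H](Nc1c(C#N)c(-c2ccc(-c3ccccc3C(C)C)cc2)nc2cnccc12)C(N)=O` follows compound 2 with a single change: 2-isopropylphenyl in place of 2-methylpyridin-3-yl on an aromatic carbon The group that leaves carries one hydrogen-bond acceptor; the group that enters carries none and has two more heavy atoms. Among the measured compounds shown here, no measured pair shows this step, so its size is uncertain. In this assay a rise beyond the scatter is expected, amounting to a number 1.20 log units higher from compound 2 to compound 4 (beyond the scatter). Compound 4 is therefore estimated at 3.1, with a range from 2.6 to 3.6.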

Compound 4, distribution coefficient: 3.5
The estimate for compound 4 lay 0.40 log units below the measured number, within the range that was stated.
By their numbers in this assay, from the lowest: compounds 2, 1 and 3 (each within the scatter of the next); then compound 4.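

At this position, on an aromatic carbon para to a large group, this assay responds strongly to the ring that is attached: 2-isopropylphenyl in place of 2-methylpyridin-3-yl gives a number 1.60 log units higher from compound 2 to compound 4 (beyond the scatter). Among the compounds shown here, this is the first step between compounds differing in one place, and it lies well beyond the scatter that separates the earlier three. No available evidence accounts for its size.

The change alters the ring nitrogen and the alkyl group together, so their shares remain unseparated. A 2-methylphenyl or 2-isopropylpyridin-3-yl group at this position would divide the step.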